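Imidazole Added to the Saturated Ring of Compound 1

The source may report more compounds than this note shows. Statements on the series, on what has been measured and on what is new or still open speak of the compounds shown alone.

Compound 1 `Cc1c(C)c2c(c(C)c1N)CC(C)(C)O2` gives 7.8 mg/kg in a functional assay on the whole organism with Mus musculus as the target (on this read-out higher numbers stand for an effect only at larger amounts of compound and lower numbers for an effect already at smaller amounts), the lowest of the two numbers in hand. Compound 3 `Cc1c(C)c2c(c(N(C)C)c1N)CC(C)(C)O2` gives 22.3 mg/kg in this assay. Compound 2 `Cc1c(C)c2c(c(N)c1N)CC(C)(C)O2` reaches only a limit of the assay, > 50 mg/kg (the limit of > 50 mg/kg in this assay, at which 1 of the 3 values shown sits). The two measured steps from compound 1, an at least 6.4-fold higher number from compound 1 to compound 2 (0.80 log units; beyond the scatter) and a 2.9-fold higher number from compound 1 to compound 3 (0.46 log units; beyond the scatter), both exchange a group on an aromatic carbon. Compound 4 `Cc1c(C)c2c(c(C)c1N)CC(C)(Cn1ccnc1)O2` differs from compound 1 in another place: 1H-imidazol-1-yl in place of hydrogen on a saturated chain carbon bound to a saturated ring carbon. Within the data shown here, no measured step touches that place, so the steps in hand do not bear on this change and give no direction; the expected step is one within the scatter, a 1.3-fold higher number from compound 1 to compound 4 (0.11 log units; within the scatter). Compound 4 is therefore estimated at 10 mg/kg, between 4 mg/kg and 30 mg/kg.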

Compound 4, dose for 50% inhibition: 25 mg/kg
Compound 4: the middle estimate sits 2.5-fold (0.40 log units) below what was measured, within the range that was stated.
By their numbers in this assay, from the lowest: compound 1; then compounds 3 and 4 (each within the scatter of the next). At a limit, above all of these: compound 2.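

The first change away from the aromatic carbons also moves the read-out in this assay: a 3.2-fold higher number from compound 1 to compound 4 (0.51 log units; beyond the scatter). This saturated chain carbon therefore responds to substitution, and the step runs in the same direction as both earlier steps from compound 1. Nothing measured in hand accounts for this step. As far as these compounds go, how an amine, a carboxylic acid or a phenyl ring would read on this carbon stays open. So does whether a longer chain carrying the 1H-imidazol-1-yl would give a different number from that of compound 4.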